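Swapping Trifluoromethyl for Methyl on the Shared Core

This account rests on a few compounds, and the source may have more. Where it says the series, first, only, none or still open, it means among the compounds named here.

Compound 1, `CCCCOC(=O)NS(=O)(=O)c1ccc(CCC)cc1-c1ccc(Cn2c(C3CCCC3)nc3ccccc32)cc1`, gives 35 nM in an assay on membranes from HEK293 cells for displacement of a labelled ligand from Type-2 angiotensin II receptor (Homo sapiens), read by radioligand binding; a lower number here means a stronger inhibitor, a higher number a weaker inhibitor.
Compound 2, `CCCCOC(=O)NS(=O)(=O)c1ccc(CCC)cc1-c1ccc(Cn2cnc3ccccc32)cc1`, gives 29 nM.
Compound 3, `CCCCOC(=O)NS(=O)(=O)c1ccc(CCC)cc1-c1ccc(Cn2c(C(F)(F)F)nc3ccccc32)cc1`, gives 13 nM.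

Compound 3 stands lowest of the three numbers; compound 2 is nearest and compound 1 furthest, and both gaps are beyond the scatter. Compound 4, `CCCCOC(=O)NS(=O)(=O)c1ccc(CCC)cc1-c1ccc(Cn2c(C)nc3ccccc32)cc1`, differs from compound 3 as follows: methyl in place of trifluoromethyl on an aromatic carbon. Among the measured compounds shown here, two measured steps bear on this position: a 2.7-fold lower number from compound 1 to compound 3 (0.43 log units; beyond the scatter) and a 2.2-fold lower number from compound 2 to compound 3 (0.35 log units; beyond the scatter), both modest, while a 1.2-fold lower number from compound 1 to compound 2 (0.08 log units; within the scatter). No methyl at this place has been measured. The steps onto trifluoromethyl were modest, so taking it away is expected to raise the number somewhat, toward compound 2. The estimate for compound 4 is 22 nM, with a range from 10 nM to 50 nM, an expected step of a 1.7-fold higher number from compound 3 to compound 4 (0.23 log units; within the scatter).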

Compound 4, inhibition constant: 9.4 nM
Compound 4: middle estimate off by 2.3-fold (0.37 log units), on the high side, and the stated range ends above it.
By their numbers in this assay, from the lowest: compounds 4 and 3 (each within the scatter of the next); then compounds 2 and 1 (each within the scatter of the next).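

In this assay, trifluoromethyl and methyl cannot be told apart at this position (a 1.4-fold lower number from compound 3 to compound 4 (0.14 log units; within the scatter)), so the fluorine atoms are not needed to keep the number low. Methyl alone also gives a modest gain over hydrogen (a 3.1-fold lower number from compound 2 to compound 4 (0.49 log units; beyond the scatter)) and over cyclopentyl (a 3.7-fold lower number from compound 1 to compound 4 (0.57 log units; beyond the scatter)), which shows that a single carbon here is enough for that gain. Nothing measured here explains these steps.

Still open, going by these compounds, is how an ethyl or propyl chain, a methoxy group or an amine at this place would compare with methyl.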